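The compounds below may be only part of what the source reports. "The series", "measured", "known", "first", "only" and "open" are said of these compounds alone.

Measured in a functional assay on HeLa cells (Homo sapiens) for antiproliferative activity, read by MTT assay, with a stated time of 48 h; a lower number here means a stronger inhibitor, a higher number a weaker inhibitor:
- compound 1 `Cc1nc2ccccc2nc1Oc1ccc(C(=O)N[C@@H](CC(C)C)C(=O)O)cc1`: 17300 nM
- compound 2 `CC(C)(C)Nc1nc2ccccc2nc1Oc1ccc(C(=O)NCC(=O)O)cc1`: > 50000 nM, a limit of the assay
- compound 3 `C[C@H](NC(=O)c1ccc(Oc2nc3ccccc3nc2NC(C)(C)C)cc1)C(=O)O`: 23400 nM

Compound 3 at 23400 nM lies within the scatter of compound 1 at 17300 nM. Next comes compound 4 `CC(C)C[C@H](NC(=O)c1ccc(Oc2nc3ccccc3nc2NC(C)(C)C)cc1)C(=O)O`: isopropyl in place of hydrogen on a saturated chain carbon, two bonds along the chain from an amide-type nitrogen and a carbonyl carbon. The change sits on a saturated chain carbon, two bonds along the chain from an amide-type nitrogen and a carbonyl carbon, and also reads as methyl to isobutyl. Among the compounds with values here, one measured step bears on this chain: methyl in place of hydrogen gave an at least 2.1-fold lower number from compound 2 to compound 3 (0.32 log units; beyond the scatter). As far as these compounds go, that step starts from the limit of > 50000 nM in this assay, at which 1 of the 3 values shown sits, so its full size is unknown. A further modest drop in this assay is therefore expected. The expected change is a 2.1-fold lower number from compound 3 to compound 4 (0.33 log units; beyond the scatter). For compound 4 the estimated value is 11000 nM, with an expected range of 4500 nM to 26000 nM.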

Compound 4, half-maximal inhibitory concentration: 39200 nM
Compound 4: the middle estimate sits 3.6-fold (0.55 log units) below what was measured; measured number outside the range, above it.
By their numbers in this assay, from the lowest: compounds 1, 3 and 4 (each within the scatter of the next, the first and the last beyond it). At a limit, above all of these: compound 2.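

In this assay, the trend set by methyl does not carry on to isobutyl at this chain carbon, where isopropyl in place of hydrogen gives a 1.7-fold higher number from compound 3 to compound 4 (0.22 log units; within the scatter). With the isobutyl chain held, (tert-butyl)amino in place of methyl on the aromatic carbon gives a 2.3-fold higher number from compound 1 to compound 4 (0.36 log units; beyond the scatter). The value of compound 2 is a limit, so the full isobutyl change from hydrogen, read as an at least 1.2-fold lower number from compound 2 to compound 4 (0.10 log units; that floor lies within the scatter), stays a floor only: the limit of > 50000 nM in this assay, at which 1 of the 4 values shown sits.

Open, as far as these compounds go, is whether a benzyl group at this chain carbon, or a methyl ester in place of the carboxylic acid, would move the number beyond the scatter.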